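This account rests on a few compounds, and the source may have more. Where it says the series, first, only, none or still open, it means among the compounds named here.

Measured so far in a physicochemical assay for lipophilicity; on this read-out higher numbers stand for higher lipophilicity and lower numbers for lower lipophilicity:
- compound 1 `Cc1c(N(C)C)c(=O)n(C)c(=O)n1C`: 0.99
- compound 2 `Nc1nc(N)nc(-c2cc(Br)ccc2Br)n1`: 2.09

Compound 1 has the lowest of the two numbers; compound 2 sits higher, a gap beyond the usual scatter of this assay. Going by the values given here, no step between measured compounds that differ in one place is available.

Compound 3 `Cc1c(N(C)C)c(=O)n(C)c(=O)n1-c1ccccc1` is not yet measured. Against compound 1 the change is phenyl in place of methyl on an aromatic nitrogen.

Without a measured step of this kind, the expectation rests on the change itself: a clear rise in this assay, well beyond the scatter, estimated as a number 1.61 log units higher from compound 1 to compound 3 (beyond the scatter). Compound 3 is accordingly expected at 2.6, in the range 2 to 3.2.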

Compound 3, partition coefficient: 1.19
Compound 3: the middle estimate sits 1.41 log units above what was measured, and the stated range ends above it.
By their numbers in this assay, from the lowest: compounds 1 and 3 (each within the scatter of the next); then compound 2.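

In this assay, phenyl in place of methyl on the aromatic nitrogen gives a number 0.20 log units higher from compound 1 to compound 3 (within the scatter). Going by these compounds alone, this is the first one-place step, and it shows that at this position, with 6 heavy atoms entering and 1 leaving, compound 1 and compound 3 cannot be told apart on this read-out. No available measurement bears on why the step is this small.

Open, from the compounds shown here alone, is whether a longer chain, an amine or a carboxylic acid on this nitrogen would stay within the scatter of compound 1. Also open, going by these compounds, is whether phenyl elsewhere on the shared core would do the same.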